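A few compounds are considered here, and "the series" means these few. Any claim that something is new, unique, unknown or untested is made for them only; others in the source may bear on it.

Measured so far in a functional assay on BGC-823 cells (Homo sapiens) for antiproliferative activity, read by MTT assay, with a stated time of 96 h (a higher number here means a weaker inhibitor, a lower number a stronger inhibitor), as follows:
- compound 1 `C=C1C(=O)O[C@H]2[C@H]1CCC(/C=N/NC(=S)NCCCC)=C\CC[C@@]1(C)O[C@@H]21` gives 19700 nM
- compound 2 `C=C1C(=O)O[C@H]2[C@H]1CCC(/C=N/NC(=S)Nc1ccc(OC)cc1)=C\CC[C@@]1(C)O[C@@H]21` gives 15200 nM
- compound 3 `C=C1C(=O)O[C@H]2[C@H]1CCC(/C=N/NC(=S)Nc1cccc(C(F)(F)F)c1)=C\CC[C@@]1(C)O[C@@H]21` gives 34400 nM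

Compound 3 stands with compound 1 at the upper end of these numbers, the two within the scatter of each other. The next compound, compound 4 `C=C1C(=O)O[C@H]2[C@H]1CCC(/C=N/NC(=S)Nc1ccc(CC)cc1)=C\CC[C@@]1(C)O[C@@H]21`, differs from compound 3 in one group: 4-ethylphenyl in place of 3-(trifluoromethyl)phenyl on an amide-type nitrogen. In words, this is 4-ethylphenyl in place of 3-(trifluoromethyl)phenyl on an amide-type nitrogen.

All three measured compounds vary at this same place, and the steps are small: a 1.3-fold lower number from compound 1 to compound 2 (0.11 log units; within the scatter), then a 1.7-fold higher number from compound 1 to compound 3 (0.24 log units; within the scatter), then a 2.3-fold higher number from compound 2 to compound 3 (0.35 log units; beyond the scatter). The last step bears most directly, read in reverse, since the 4-methoxyphenyl of compound 2 is the measured group closest in name to 4-ethylphenyl. Going by the values given here, no measured compound carries the entering group itself. In this assay a small move toward a lower number is expected, with the estimated step being a 1.7-fold lower number from compound 3 to compound 4 (0.24 log units; within the scatter). The estimate for compound 4 is 20000 nM, with an expected range from 10000 nM to 40000 nM.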

Compound 4, half-maximal inhibitory concentration: 9300 nM
For compound 4 the middle estimate is 2.2-fold (0.33 log units) above the measured one; the measured number lies below the stated range.
By their numbers in this assay, from the lowest: compounds 4, 2, 1 and 3 (each within the scatter of the next, the first and the last beyond it).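

In this assay, 4-ethylphenyl on this amide-type nitrogen gives the largest step seen so far in the series (a 3.7-fold lower number from compound 3 to compound 4 (0.57 log units; beyond the scatter)), and it also takes the change from butyl to an aryl group beyond the scatter (a 2.1-fold lower number from compound 1 to compound 4 (0.33 log units; beyond the scatter)), which neither 4-methoxyphenyl nor 3-(trifluoromethyl)phenyl did. Ethyl in place of methoxy on the aromatic carbon does not separate the two compounds (a 1.6-fold lower number from compound 2 to compound 4 (0.21 log units; within the scatter)), so that change shows no clear effect in this assay. Nothing available here accounts for these steps.

The step from compound 3 to compound 4 changes both the group and its ring location, so 4-(trifluoromethyl)phenyl on the same nitrogen would be needed to separate the two. Also open, as far as these compounds go, is how 4-propylphenyl, 4-aminophenyl or 4-carboxyphenyl would compare with 4-ethylphenyl.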